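The source may hold more compounds than are shown below. What is called first, only, known or untested is meant among the compounds shown, and "the series" means these compounds.

Compound 1 `Cc1ccc(S(=O)(=O)NC(C)C)cc1C#Cc1cc(Cl)ccc1OCC(=O)O` is one of three compounds tested in an assay on CHO cells for displacement of a labelled ligand from prostaglandin D2 receptor 2 (Homo sapiens), read by scintillation counting (a higher number here means a weaker inhibitor, a lower number a stronger inhibitor), where compound 1 gives 3.4 nM. Its neighbours are compound 3 `CCCS(=O)(=O)c1ccc(C)c(C#Cc2cc(Cl)ccc2OC(C)C(=O)O)c1`, which in this assay gives 1.2 nM, and compound 2 `CCCS(=O)(=O)c1cccc(C#Cc2c(OCC(=O)O)cccc2-c2sc(C)nc2C)c1`, which in this assay gives 54 nM. Compound 1 thus stands second highest of the three, with compound 3 the nearer and compound 2 the further number, both gaps beyond the scatter.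

Compound 4 `CCN(CC)S(=O)(=O)c1ccc(C)c(C#Cc2cc(Cl)ccc2OCC(=O)O)c1` keeps the core of compound 1 and differs only in one place: diethylamino in place of isopropylamino on a sulfonyl sulfur. For the measured compounds named here, no measured pair shows this change. Its step is expected to be small, a 1.3-fold higher number from compound 1 to compound 4 (0.12 log units; within the scatter), not clearly beyond the scatter in either direction. Compound 4 is therefore estimated at 4.5 nM, within 1.5 nM to 14 nM.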

Compound 4, inhibition constant: 3.4 nM
For compound 4 the middle estimate is 1.3-fold (0.12 log units) above the measured one; measured number inside the range.
By their numbers in this assay, from the lowest: compound 3; then compounds 1 and 4 (each within the scatter of the next); then compound 2.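

At this position on the sulfonyl sulfur, diethylamino replaces isopropylamino, and this assay gives no change at the digits printed from compound 1 to compound 4 (within the scatter). The swap takes away the hydrogen-bond donor counted on isopropylamino and adds a heavy atom, yet the two compounds cannot be told apart, so that donor is not needed here for a number of this size. Nothing measured here explains this result.

The compounds shown leave open whether a plain amino group or a morpholine ring on the sulfonyl sulfur would read alike. They also leave open whether the same swap holds on other cores.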